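Dimethoxy Pattern Shift on a Styryl Lactone Scaffold

The compounds below may be only part of what the source reports. "The series", "measured", "known", "first", "only" and "open" are said of these compounds alone.

Measured compounds:
compound 1 `O=C1C=CCC(/C=C/c2ccc(C(F)(F)F)cc2)O1` — 51 uM
compound 2 `COc1ccc(/C=C/C2CC=CC(=O)O2)cc1` — 25.5 uM
compound 3 `COc1ccc(/C=C/C2CC=CC(=O)O2)c(OC)c1` — 5.4 uM

In a functional assay on MCF7 cells (Homo sapiens) for inhibition, read by sulforhodamine B assay, with a stated time of 48 h (on this read-out higher numbers stand for weaker inhibition of growth and lower numbers for stronger inhibition of growth), compound 2 gives 25.5 uM, the second highest of the three numbers. Its nearest neighbour is compound 1, and the gap there is a 2.0-fold lower number from compound 1 to compound 2 (0.30 log units; within the scatter); its furthest is compound 3, reached by a 4.7-fold lower number from compound 2 to compound 3 (0.67 log units; beyond the scatter). Compound 4 `COc1ccc(/C=C/C2CC=CC(=O)O2)cc1OC` has not yet been measured. It differs from compound 2 in one place: methoxy in place of hydrogen on an aromatic carbon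

For the measured compounds named here, only one measured step bears on this change: the step with a methoxy in place of hydrogen on an aromatic carbon, a 4.7-fold lower number from compound 2 to compound 3 (0.67 log units; beyond the scatter), a modest drop beyond the scatter. Going by the values given here, that step placed the methoxy at a different aromatic carbon than the one entering in compound 4, so the precedent is imperfect. The step with methoxy in place of trifluoromethyl on an aromatic carbon, a 2.0-fold lower number from compound 1 to compound 2 (0.30 log units; within the scatter), lay within the scatter and says little here. A second methoxy, ortho to the existing methoxy group, is therefore expected to lower the number in this assay modestly. For compound 4 the estimated value is 10 uM (range 4 uM to 25 uM), a step of a 2.6-fold lower number from compound 2 to compound 4 (0.41 log units; beyond the scatter) that is expected because of a 4.7-fold lower number from compound 2 to compound 3 (0.67 log units; beyond the scatter).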

Compound 4, concentration for growth inhibition (reported as GI): 7.8 uM
Compound 4: middle estimate off by 1.3-fold (0.11 log units), on the high side; the measured number falls inside the stated range.
By their numbers in this assay, from the lowest: compounds 3 and 4 (each within the scatter of the next); then compounds 2 and 1 (each within the scatter of the next).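

At this aromatic carbon, ortho to a methoxy group, methoxy in place of hydrogen also lowers the number in this assay, with a 3.3-fold lower number from compound 2 to compound 4 (0.51 log units; beyond the scatter). For the compounds shown here, the only earlier step of this kind, a 4.7-fold lower number from compound 2 to compound 3 (0.67 log units; beyond the scatter), placed the methoxy at a different aromatic carbon, so the change now lies beyond the scatter at two carbons of the ring of compound 2. No measurement shown here explains why this methoxy has this effect.

The compounds shown leave open whether the drop is particular to methoxy, or whether a hydroxyl, a fluorine atom or a longer chain such as ethoxy at this carbon would give the same result. They also leave open whether a methoxy at this carbon lowers the number without the methoxy already on the ring.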